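Swapping methyl for tert-butyl on the aromatic ring

This account rests on a few compounds, and the source may have more. Where it says the series, first, only, none or still open, it means among the compounds named here.

This set centres on one measurement in an assay on isolated protein for inhibition of Dihydrofolate reductase (Homo sapiens), read by spectrophotometry, using NADPH, with stated times of 5 s and 6 min; on this read-out higher numbers stand for weaker inhibition and lower numbers for stronger inhibition. Compound 1, `NC1=NC2(CCOCC2)N(OCCCOc2cccc(Cl)c2)C(N)=N1`, stands in this assay with "not determined" (no result reported), that is, without a reported number. For the measured compounds named here, compound 2, `Cc1ccc(OCCCON2C(N)=NC(N)=NC23CCOCC3)cc1`, is the only member with a number: in this assay compound 2 gives 56.8 nM, so it stands alone as the reference point, with no second value to compare it against.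

Compound 3, `CC(C)(C)c1ccc(OCCCON2C(N)=NC(N)=NC23CCOCC3)cc1`, is not yet measured. It differs from compound 2 in a single spot: tert-butyl in place of methyl on an aromatic carbon. Going by the values given here, no step between two measured compounds is available to calibrate how such a change behaves here, so the expectation for compound 3 leans on compound 2 alone. The step from compound 2 to compound 3 is expected to be small, a 1.3-fold lower number from compound 2 to compound 3 (0.10 log units; within the scatter), and to stay within or only just beyond the usual scatter. On that basis compound 3 is estimated at 45 nM in this assay, with a plausible range from 15 nM to 150 nM.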

Compound 3, half-maximal inhibitory concentration: 3.72 nM
The estimate for compound 3 lay 12-fold (1.08 log units) above the measured number; measured number below the stated range.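

In this assay, tert-butyl in place of methyl on this aromatic carbon, para to a large group, gives a 15-fold lower number from compound 2 to compound 3 (1.18 log units; beyond the scatter), so this position clearly affects the read-out, which compound 2 alone could not show. Neither group has a ring, a hydrogen-bond donor, a hydrogen-bond acceptor or a net charge, so this large step comes from exchanging one carbon group for a bigger carbon group. No measurement shown here explains why the number falls so far.

The two values cannot show whether the number would fall gradually through intermediate groups such as ethyl or isopropyl, or whether tert-butyl is a special case. Going by these compounds, it also remains open how an amine or a carboxylic acid would behave on the same carbon.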